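The source may report more compounds than this note shows. Statements on the series, on what has been measured and on what is new or still open speak of the compounds shown alone.

Compound 1 `COc1ccc(Cl)cc1Cn1c(C(=O)NCC(C)(C)CO)cc2cc(C#N)ccc21`: 63 mL.min-1.g-1
Compound 2 `COc1ccc(C)cc1Cn1c(C(=O)NCC(C)(C)CO)cc2cc(C#N)ccc21`: 64 mL.min-1.g-1

In an in vitro ADME assay on microsomes from Gut (Homo sapiens) for metabolic stability, in the presence of a further agent that is not named here (on this read-out higher numbers stand for fast clearance and lower numbers for slow clearance), compound 2 gives 64 mL.min-1.g-1 and compound 1 gives 63 mL.min-1.g-1. Going by the values given here, these two values lie within the scatter of each other, so compound 2 cannot be separated from the only other measured compound. Compound 3 `CCCOc1cccc(Cn2c(C(=O)NCC(C)(C)CO)cc3cc(C#N)ccc32)c1` keeps the shared core and the amide side chain of compound 2, but carries 3-propoxyphenyl in place of 2-methoxy-5-methylphenyl on a saturated chain carbon bound to an aromatic nitrogen.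

Among the compounds with values here, the sole measured step is a 1.0-fold higher number from compound 1 to compound 2 (0.01 log units; within the scatter), which stays within the scatter. It shows only that methyl in place of chloro left this assay unmoved. It does not test the loss of the 2-methoxy-5-methylphenyl group, so the data give no firm direction for the new change. The step expected is therefore none beyond the scatter, and the estimate is a 1.1-fold higher number from compound 2 to compound 3 (0.04 log units; within the scatter). Within the data shown here, the range is kept wide since no measured compound carries 3-propoxyphenyl. For compound 3 the expected value is 70 mL.min-1.g-1, estimated to fall between 32 mL.min-1.g-1 and 150 mL.min-1.g-1.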

Compound 3, intrinsic clearance in microsomes: 45 mL.min-1.g-1
Compound 3: the middle estimate sits 1.6-fold (0.19 log units) above what was measured, and the stated range covers the measured number.
By their numbers in this assay, from the lowest: compounds 3, 1 and 2 (each within the scatter of the next).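

In this assay the earlier pair tested only methyl in place of chloro, while here the whole group on the saturated chain carbon bound to an aromatic nitrogen is exchanged, giving a 1.4-fold lower number from compound 2 to compound 3 (0.15 log units; within the scatter) and, for the exchange with 5-chloro-2-methoxyphenyl, a 1.4-fold lower number from compound 1 to compound 3 (0.15 log units; within the scatter). Going by these compounds alone, both steps stay within the scatter, so this position accepts 3-propoxyphenyl, 2-methoxy-5-methylphenyl and 5-chloro-2-methoxyphenyl without any separation on this read-out, even though the exchange alters more of the group than the single swap of methyl for chloro did. Nothing measured here bears on the reason for this result.

Going by these compounds, it stays open whether any group at this position can move the read-out beyond the scatter, for example a phenyl ring carrying an amine or a carboxylic acid, or one with a longer chain such as butoxy in place of propoxy. On these data alone, the amide side chain and the shared core are the same in all three compounds, so what a change in either part would do to the clearance remains unknown.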